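The source may hold more compounds than are shown below. What is called first, only, known or untested is meant among the compounds shown, and "the series" means these compounds.

Three members of the shared core have numbers in a functional assay on K562 cells (Homo sapiens) for inhibition, read by MTT assay, with a stated time of 72 h; a lower number here means a stronger inhibitor, a higher number a weaker inhibitor. Compound 1 `CCc1ccc(C(=O)/C=C/C(=O)O)cc1` gives 5530 nM in this assay. Compound 2 `CC(C)c1cc(C(C)C)c(C(=O)/C=C/C(=O)O)c(C(C)C)c1` gives 4670 nM in this assay, and compound 3 `O=C(O)/C=C/C(=O)c1cc(C2CCCCC2)ccc1C1CCCCC1` gives 3320 nM in this assay. The number of compound 1 is the highest of the three, but its gap to compound 2 and its gap to compound 3 both lie within the usual scatter of this kind of measurement, so no ranking among the three is supported by the data.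

Compound 4 `CC(C)c1ccc(C(=O)/C=C/C(=O)O)cc1` has not yet been measured in this assay. It differs from compound 1 in a single place: methyl in place of hydrogen on a saturated chain carbon bound to an aromatic carbon and a saturated chain carbon. Going by the values given here, no pair of measured compounds in this set differs in only one place, so the size of such a change has no direct precedent here. The three measured compounds carry quite different groups on the core and yet all fall within scatter of one another, which gives no sign that one added carbon would move the number far. The step from compound 1 to compound 4 is therefore expected to be small, in either direction, and most likely not beyond the scatter. The expected step is a 1.2-fold lower number from compound 1 to compound 4 (0.09 log units; within the scatter). Compound 4 is expected to give 4500 nM in this assay, with a range from 2200 nM to 9000 nM.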

Compound 4, half-maximal inhibitory concentration: 5560 nM
Compound 4: the middle estimate sits 1.2-fold (0.09 log units) below what was measured; measured number inside the range.
By their numbers in this assay, from the lowest: compounds 3, 2, 1 and 4 (each within the scatter of the next).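

Going by these compounds alone, the first single-place comparison, ethyl to isopropyl, reads in this assay as a 1.0-fold higher number from compound 1 to compound 4 (0.00 log units; within the scatter). At this place, a saturated chain carbon bound to an aromatic carbon and a saturated chain carbon, methyl in place of hydrogen therefore gives no difference that can be read in this assay, which is direct information that the spread among compounds with different groups could not supply. No accompanying measurement bears on why compound 1 and compound 4 read alike.

The compounds shown cover only one small change at this place, so it remains open whether a tert-butyl group, a longer chain such as n-hexyl, or a polar substituent such as a hydroxyl or an amine at the same carbon would also stay within the scatter. Also open, as far as these compounds go, is how much the number depends on the rest of the shared core, for instance whether a methyl ester or an amide in place of the carboxylic acid, with the isopropyl group of compound 4 kept, would give a step beyond the scatter.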